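Macrocyclic anilinoquinazolines: benzyloxy substituent and antiproliferative potency

This account rests on a few compounds, and the source may have more. Where it says the series, first, only, none or still open, it means among the compounds named here.

Measured compounds:
compound 1 `FC(F)(F)c1ccc(COc2cccc(Nc3ncnc4cc5c(cc34)OCCOCCOCCO5)c2)cc1`, 17600 nM
compound 2 `FC(F)(F)c1ccc(COc2ccc(Nc3ncnc4cc5c(cc34)OCCOCCOCCOCCO5)cc2)cc1`, 10000 nM
compound 3 `O=[N+]([O-])c1ccc(COc2ccc(Nc3ncnc4cc5c(cc34)OCCOCCOCCOCCO5)cc2)cc1`, > 100000 nM

In a functional assay on MCF7 cells (Homo sapiens) for antiproliferative activity, read by MTT assay, with a stated time of 72 h (on this read-out higher numbers stand for weaker inhibition and lower numbers for stronger inhibition), compound 1 gives 17600 nM and compound 2 gives 10000 nM. Compound 3 reaches only the limit of the assay, > 100000 nM, so no number is known for it; it sits at the limit of > 100000 nM in this assay, at which 1 of the 3 values shown sits. For the measured compounds named here, the one step that bears on the benzyloxy substituent is an at least 10-fold higher number from compound 2 to compound 3 (1.00 log units; beyond the scatter), and it runs towards weaker inhibition.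

Compound 4 `c1ccc(COc2ccc(Nc3ncnc4cc5c(cc34)OCCOCCOCCOCCO5)cc2)cc1` is not yet measured. It differs from compound 3 by hydrogen in place of nitro on an aromatic carbon. Hydrogen in place of nitro removes the group that accompanied the loss of measurable activity in the step from trifluoromethyl to nitro, so the number for compound 4 is expected to come back towards that of compound 2 rather than stay at the limit; the direction of an at least 3.3-fold lower number from compound 3 to compound 4 (0.52 log units; beyond the scatter) is therefore expected to be downward, towards stronger inhibition, though its size is uncertain because compound 3 is a limit > 100000 nM. Compound 4 is expected to give about 30000 nM, between 8000 nM and 150000 nM.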

Compound 4, half-maximal inhibitory concentration: 12000 nM
The estimate for compound 4 lay 2.5-fold (0.40 log units) above the measured number, within the range that was stated.
By their numbers in this assay, from the lowest: compounds 2, 4 and 1 (each within the scatter of the next). At a limit, above all of these: compound 3.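

In this assay, hydrogen in place of nitro on the aromatic carbon para to a large group gives an at least 8.3-fold lower number from compound 3 to compound 4 (0.92 log units; beyond the scatter), so the loss of a measurable number in this pair goes with the nitro group and not with the benzyloxy frame itself. Compound 3 alone stands at a limit and not at a number, so this step is a bound and not a size: the limit of > 100000 nM in this assay, at which 1 of the 4 values shown sits. Hydrogen in place of trifluoromethyl gives a 1.2-fold higher number from compound 2 to compound 4 (0.08 log units; within the scatter), so these two groups cannot be told apart at this position in this assay, and among the three groups shown only nitro goes with a reading at the limit.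

As far as these compounds go, whether other groups at this place, such as an amine, a nitrile or a carboxylic acid, would stay with hydrogen and trifluoromethyl or go with nitro remains open. Compound 1 differs from compound 2 in more than one place, so the effects of macrocycle size and of where the benzyloxy group sits remain unseparated.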